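The compounds below may be only part of what the source reports. "The series", "measured", "known", "first", "only" and "open" are said of these compounds alone.

Measured so far:
compound 1 `COc1ccc(N(C)c2nc(C)nc3ccccc23)cc1OCCC[Se]C#N` — 921 nM
compound 2 `Cc1nc(N(C)c2ccc([Se]C#N)c(F)c2)c2ccccc2n1` — 13 nM

In a functional assay on LoVo cells (Homo sapiens) for inhibition, read by MTT assay, with a stated time of 48 h (a higher number here means a weaker inhibitor, a lower number a stronger inhibitor), compound 1 gives 921 nM, the higher of the two numbers; compound 2 gives 13 nM, and the gap between the two lies beyond the scatter. Compound 3 `COc1ccc(N(C)c2nc(C)nc3ccccc23)cc1OCCN` is not yet measured. It differs from compound 1 in one place: one nitrogen atom in place of a group of 4 heavy atoms (2 carbon, 1 nitrogen, 1 selenium; no ring), on a saturated chain carbon, two bonds along the chain from an oxygen on an aromatic ring. Both measured compounds carry selenium; compound 3 carries none, so the step is into ground the two numbers do not cover. Going by the values given here, no step between measured compounds that share this change exists to set its size. Given that compound 1 already stands at the weaker end with 921 nM, the expectation is a move toward a higher number for compound 3, of a size beyond the scatter, rather than none. For compound 3 the expected step from the parent is a 5.4-fold higher number from compound 1 to compound 3 (0.73 log units; beyond the scatter). Compound 3 is estimated at 5000 nM, within 1500 nM to 20000 nM, an expectation and not a measurement.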

Compound 3, half-maximal inhibitory concentration: 421 nM
Compound 3: the middle estimate sits 12-fold (1.07 log units) above what was measured; measured number outside the range, below it.
By their numbers in this assay, from the lowest: compound 2; then compound 3; then compound 1.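

At the saturated chain carbon, two bonds along the chain from an oxygen on an aromatic ring, amino in place of the selenium-containing group gives a 2.2-fold lower number from compound 1 to compound 3 (0.34 log units; beyond the scatter) in this assay, a modest move. Selenium is therefore not required for activity in this series: compound 3 carries none and still reads 421 nM in this assay. Nothing at hand bears on why the number moves in this direction.

On these data alone, it remains open whether a dimethylamino group, a hydroxyl or a carboxylic acid at the same chain carbon would give a lower or higher number, and how a longer chain carrying the amino group would read. Also open, as far as these compounds go, is how much of the step comes from losing the selenium-containing group and how much from gaining amino.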